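Chloro for Methyl: From Compound 2 to Compound 3

The source may report more compounds than this note shows. Statements on the series, on what has been measured and on what is new or still open speak of the compounds shown alone.

In a functional assay on the whole organism (strain Wistar albino) for inhibition, with Rattus norvegicus as the target, read by paw edema, with a stated time of 2 h, at a dose of 25 mg/kg by the oral route (on this read-out lower numbers stand for less inhibition and higher numbers for more inhibition at the one dose given (going by the name of the read-out)), compound 2 `Cc1ccc(Nc2nn(-c3ccccc3)c3nc(Nc4ccccc4)n(-c4ccccc4)c(=O)c23)cc1` gives 53.4%, the higher of the two numbers measured; compound 1 `CSc1nn(-c2ccccc2)c2nc(Nc3ccccc3)n(-c3ccccc3)c(=O)c12` gives 36.6%, and the step of a number 16.8 percentage points higher from compound 1 to compound 2 (beyond the scatter) is a gain beyond the scatter. Compound 3 `O=c1c2c(Nc3ccc(Cl)cc3)nn(-c3ccccc3)c2nc(Nc2ccccc2)n1-c1ccccc1` differs from compound 2 in one place: chloro in place of methyl on an aromatic carbon. Going by the values given here, the one measured step swapped methylsulfanyl for (4-methylphenyl)amino, a different change, so nothing measured here bears on exchanging methyl for chloro. The step of a number 0.4 percentage points lower from compound 2 to compound 3 (within the scatter) is therefore expected to stay within the scatter. Compound 3 is estimated at 53%, between 35% and 70%.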

Compound 3, a percentage reported as inhibition, in the whole organism at one dose (the size of the read-out at that dose, not a potency): 44%
Compound 3: the middle estimate sits 9 percentage points above what was measured; the range from low to high includes it.
By their numbers in this assay, from the lowest: compounds 1, 3 and 2 (each within the scatter of the next, the first and the last beyond it).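

In this assay chloro in place of methyl on this aromatic carbon gives a number 9.4 percentage points lower from compound 2 to compound 3 (within the scatter) and so leaves the two groups indistinguishable here. Against compound 1, (4-chlorophenyl)amino in place of methylsulfanyl gives a number 7.4 percentage points higher from compound 1 to compound 3 (within the scatter) and so does not repeat the clear gain that (4-methylphenyl)amino showed. No evidence is available to explain these results.

Still open, going by these compounds, is whether methoxy, nitro or a plain hydrogen at this carbon would separate from methyl and chloro. Also open, on these data alone, is whether a different amine in place of the arylamino group would shift the number beyond the scatter.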